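The compounds below may be only part of what the source reports. "The series", "measured", "known", "first", "only" and "open" are said of these compounds alone.

Three esters built on one shared core have been measured for metabolic stability. In an ADME assay on microsomes from liver (Mus musculus) for metabolic stability, with a stated time of 30 min (a lower number here means that less of the compound is left, a higher number that more of the compound is left), compound 1 `CCCCc1nc(C(C)C)c(CC(=O)OC2CC2)c(=O)n1Cc1ccc(-c2ccccc2-c2noc(=O)[nH]2)cc1` gives 11.4%, compound 2 `CCCCc1nc(C)c(CC(=O)OC(C)C)c(=O)n1Cc1ccc(-c2ccccc2-c2noc(=O)[nH]2)cc1` gives 4%, and compound 3 `CCCCc1nc(C)c(CC(=O)OCC(C)C)c(=O)n1Cc1ccc(-c2ccccc2-c2noc(=O)[nH]2)cc1` gives 7.7%. Compound 3 stands second highest of the three numbers, though its gaps to compound 1 and to compound 2 both lie within the scatter. Compound 4 `CCCCc1nc(C)c(CC(=O)OC2CC2)c(=O)n1Cc1ccc(-c2ccccc2-c2noc(=O)[nH]2)cc1` differs from compound 3 by cyclopropyl in place of isobutyl on an oxygen next to a carbonyl group. For the measured compounds named here, the only measured step at that oxygen, a number 3.7 percentage points higher from compound 2 to compound 3 (within the scatter), changed little. Compound 1, which carries the same cyclopropyl ester, gives 11.4% in this assay, close to compound 3. The expected step of a number 0.3 percentage points higher from compound 3 to compound 4 (within the scatter) is therefore none beyond the scatter. Compound 4 is estimated at 8%, within 3% to 14%.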

Compound 4, percent of the compound remaining: 12.8%
Compound 4: middle estimate off by 4.8 percentage points, on the low side, within the range that was stated.
By their numbers in this assay, from the lowest: compounds 2, 3, 1 and 4 (each within the scatter of the next).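

With cyclopropyl on an oxygen next to a carbonyl group, this assay gives a number 5.1 percentage points higher from compound 3 to compound 4 (within the scatter) and a number 8.8 percentage points higher from compound 2 to compound 4 (within the scatter), so cyclopropyl, isobutyl and isopropyl at this oxygen are not separated beyond the scatter. The change on an aromatic carbon, methyl in place of isopropyl, is also not separated, with a number 1.4 percentage points higher from compound 1 to compound 4 (within the scatter). No measured property bears on these steps. The compounds shown leave open whether a longer chain on that oxygen, or an amide in place of the ester, would move the number beyond the scatter.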